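Swapping the aryl group on the amide nitrogen

The source may report more compounds than this note shows. Statements on the series, on what has been measured and on what is new or still open speak of the compounds shown alone.

Compound 1 `CC(C)(C)NC(=O)CCc1cccc2c1B(O)OC2`: > 100000 nM (limit)
Compound 2 `Cc1ccc(NC(=O)CCc2cccc3c2B(O)OC3)cc1`: 1100 nM

Going by the values given here, in a functional assay on MDA-MB-231 cells (Homo sapiens) for antiproliferative activity, read by MTT assay, with a stated time of 72 h (a higher number here means a weaker inhibitor, a lower number a stronger inhibitor), compound 2 gives 1100 nM, the only true number so far. Compound 1 gives > 100000 nM, which is a limit of the assay. Among the compounds with values here, the sole measured step, an at least 90-fold lower number from compound 1 to compound 2 (1.95 log units; beyond the scatter), is large, but it starts from the limit of > 100000 nM in this assay, at which 1 of the 2 values shown sits, and replaces tert-butyl, so it offers little guidance on exchanging one phenyl group for another.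

Compound 3 `O=C(CCc1cccc2c1B(O)OC2)Nc1cccc(I)c1` differs from compound 2 by 3-iodophenyl in place of 4-methylphenyl on an amide-type nitrogen, with 3-iodophenyl in place of 4-methylphenyl on an amide-type nitrogen. The expected result is a 1.1-fold higher number from compound 2 to compound 3 (0.04 log units; within the scatter), with no change beyond the scatter in either direction. Compound 3 is estimated at 1200 nM, with an expected range of 300 nM to 5000 nM.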

Compound 3, half-maximal inhibitory concentration: 5300 nM
The estimate for compound 3 lay 4.4-fold (0.65 log units) below the measured number; measured number above the stated range.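

With true numbers at both ends, the exchange of one aryl group for another on the amide-type nitrogen proves not to be neutral in this assay: a 4.8-fold higher number from compound 2 to compound 3 (0.68 log units; beyond the scatter) puts 3-iodophenyl behind 4-methylphenyl, although the count of heavy atoms is unchanged. Compound 3 still keeps a large margin over the tert-butyl amide, with an at least 18-fold lower number from compound 1 to compound 3 (1.27 log units; beyond the scatter). That step is only a bound, as its starting point for compound 1 is a limit: the limit of > 100000 nM in this assay, at which 1 of the 3 values shown sits.

Compound 2 and compound 3 differ in both the substituent and the place it occupies on the ring, so the two contributions remain unseparated. A 3-methylphenyl or 4-iodophenyl group on the same nitrogen would tell them apart.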